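Aryl swap on the ring nitrogen of compound 2

A few compounds are considered here, and "the series" means these few. Any claim that something is new, unique, unknown or untested is made for them only; others in the source may bear on it.

The series shares one core and varies the aromatic group on an amine nitrogen in a ring. Compound 2 `Nc1scc(CN2CCN(c3ccc(Cl)c(C(F)(F)F)c3)CC2)c1C(=O)c1ccc(Cl)cc1`, compound 1 `Nc1scc(CN2CCN(c3ccc([N+](=O)[O-])cc3)CC2)c1C(=O)c1ccc(Cl)cc1` and compound 3 `Nc1scc(CN2CCN(c3ccc(C(F)(F)F)cc3)CC2)c1C(=O)c1cccc(C(F)(F)F)c1` have been measured in an assay on CHO cells for displacement of a labelled ligand from adenosine receptor A3 (Homo sapiens), read by scintillation counting, with a stated time of 120 min, tested at 10 uM; on this read-out higher numbers stand for more inhibition at the one concentration tested (going by the name of the read-out) and lower numbers for less inhibition. Compound 2 gives 3%. Compound 1 gives 2% and compound 3 gives 0%, and all three numbers lie within the scatter of one another, so no order among them can be read from these data. Among the measured compounds shown here, the only measured step that touches the same place is a number 1 percentage points higher from compound 1 to compound 2 (within the scatter), a change of the aromatic group on the ring nitrogen without any movement beyond the scatter.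

Compound 4 `Nc1scc(CN2CCN(c3cccc(F)c3)CC2)c1C(=O)c1ccc(Cl)cc1` is not yet measured. It differs from compound 2 in that place alone: 3-fluorophenyl in place of 4-chloro-3-(trifluoromethyl)phenyl on an amine nitrogen in a ring. For the measured compounds named here, no measured pair carries 3-fluorophenyl, so the expectation rests on the one step at this position, which was within the scatter, and on the flat spread of the three numbers. In this assay the step from compound 2 to compound 4 is therefore expected to be a number 1 percentage points lower from compound 2 to compound 4 (within the scatter), that is, no movement beyond the scatter. Compound 4 is estimated at 2%, with a range from -5% to 10%.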

Compound 4, a percentage reported as inhibition, at one concentration (the size of the read-out at that concentration, not a potency): 4%
Estimate against measurement, compound 4: 2 percentage points below; the range from low to high includes it.
By their numbers in this assay, from the lowest: compounds 3, 1, 2 and 4 (each within the scatter of the next).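

In this assay the exchange of aryl groups on the ring nitrogen reads as a number 1 percentage points higher from compound 2 to compound 4 (within the scatter) and as a number 2 percentage points higher from compound 1 to compound 4 (within the scatter) in the second comparison, so neither step moves beyond the scatter. The step from compound 2 to compound 4 removes the chlorine and the trifluoromethyl group and takes the aryl group from 11 heavy atoms to 7, and this reduction leaves the reading within the scatter, as the earlier swap from 4-nitrophenyl to 4-chloro-3-(trifluoromethyl)phenyl did. Compounds 1, 2 and 4 now give three aryl groups on one shared core with no order among them, and nothing measured here accounts for this flat reading.

All of these readings sit close to zero inhibition at the one concentration tested, so they cannot show whether a difference between these aryl groups would appear in a series with a higher reading. Open, on these data alone, is whether an aryl group bearing an amine or a carboxylic acid, or a longer alkyl chain in place of the aryl group on the ring nitrogen, would move the number beyond the scatter.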